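The source may hold more compounds than are shown below. What is called first, only, known or untested is meant among the compounds shown, and "the series" means these compounds.

Compound 1 `COc1cccc(/C=C2\CCC/C(=C\c3cccc(OC)c3OC)C2=O)c1`: 9900 nM
Compound 2 `COc1ccc(/C=C2\CCC/C(=C\c3cccc(OC)c3OC)C2=O)cc1OC`: 6400 nM
Compound 3 `COc1cc(/C=C2\CCC/C(=C\c3cccc(OC)c3OC)C2=O)cc(OC)c1`: 4500 nM

In a functional assay on HT-1080 cells (Homo sapiens) for cytotoxicity, read by MTT assay, with a stated time of 72 h (on this read-out higher numbers stand for weaker inhibition and lower numbers for stronger inhibition), compound 3 lies modestly under compound 1, while compound 3 and compound 2 sit within the scatter of each other. Compound 4 `COc1cccc(/C=C2\CCC/C(=C\c3cc(OC)c(OC)c(OC)c3)C2=O)c1OC` differs from compound 3 in one place: methoxy in place of hydrogen on an aromatic carbon. The same kind of swap, methoxy in place of hydrogen on an aromatic carbon, has been measured twice. One case is a 1.5-fold lower number from compound 1 to compound 2 (0.19 log units; within the scatter), and the other is a 2.2-fold lower number from compound 1 to compound 3 (0.34 log units; beyond the scatter). Both went downward and neither was large, so a small further drop is expected, perhaps none beyond the scatter. The expected change is a 1.4-fold lower number from compound 3 to compound 4 (0.15 log units; within the scatter). The estimate for compound 4 is 3200 nM, with an expected range of 1300 nM to 7000 nM.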

Compound 4, half-maximal inhibitory concentration: 2300 nM
Estimate against measurement, compound 4: 1.4-fold (0.14 log units) above; the range from low to high includes it.
By their numbers in this assay, from the lowest: compounds 4, 3, 2 and 1 (each within the scatter of the next, the first and the last beyond it).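

The new methoxy, ortho to two methoxy groups and para to a large group, gives a 2.0-fold lower number from compound 3 to compound 4 (0.29 log units; within the scatter) in this assay, and this step matches the earlier one made at the same place: the same change on two cores in this assay, a 1.5-fold lower number (0.19 log units; within the scatter) from compound 1 to compound 2 and a 2.0-fold lower number (0.29 log units; within the scatter) from compound 3 to compound 4, 1.3-fold (0.10 log units) apart, within the scatter of two such steps

A methoxy added at the other open place on that ring gives a 2.8-fold lower number from compound 2 to compound 4 (0.44 log units; beyond the scatter), which also repeats an earlier step: the same change on two cores in this assay, a 2.2-fold lower number (0.34 log units; beyond the scatter) from compound 1 to compound 3 and a 2.8-fold lower number (0.44 log units; beyond the scatter) from compound 2 to compound 4, 1.3-fold (0.10 log units) apart, within the scatter of two such steps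

Across these four compounds, each methoxy therefore counted about the same whether or not the other was already there.

Still open, as far as these compounds go, is whether a hydroxyl, an amine or a longer chain at these places would lower the number as methoxy does.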